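Iodo for chloro on the benzyl ring

This account rests on a few compounds, and the source may have more. Where it says the series, first, only, none or still open, it means among the compounds named here.

Measured so far:
compound 1 `O[C@@H]1[C@H](O)CS[C@H]1Cn1cnc2c(NCc3cccc(Br)c3)nc(Cl)nc21` gives 23.6% in an assay on CHO cells for displacement of a labelled ligand from adenosine receptor A1 (Homo sapiens), with a stated time of 60 min, tested at 10 uM; on this read-out higher numbers stand for more inhibition at the one concentration tested (going by the name of the read-out) and lower numbers for less inhibition
compound 2 `O[C@@H]1[C@H](O)CS[C@H]1Cn1cnc2c(NCc3cccc(Cl)c3)nc(Cl)nc21` gives 3.2%

Compound 2 stands lowest of the two numbers, with compound 1 the nearer. Compound 3 `O[C@@H]1[C@H](O)CS[C@H]1Cn1cnc2c(NCc3cccc(I)c3)nc(Cl)nc21` differs from compound 2 by iodo in place of chloro on an aromatic carbon. Among the measured compounds shown here, one measured step bears on this position: a number 20.4 percentage points lower from compound 1 to compound 2 (beyond the scatter). The move to compound 3 goes the other way, so a rise is expected, of about a number 26.8 percentage points higher from compound 2 to compound 3 (beyond the scatter). Compound 3 is therefore estimated at 30%, within a range from 5% to 55%.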

Compound 3, a percentage reported as inhibition, at one concentration (the size of the read-out at that concentration, not a potency): 16.4%
Estimate against measurement, compound 3: 13.6 percentage points above; low and high end bracket the measured number.
By their numbers in this assay, from the lowest: compound 2; then compounds 3 and 1 (each within the scatter of the next).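

In this assay, iodo gives a number 13.2 percentage points higher from compound 2 to compound 3 (beyond the scatter) and so compound 2 now sits beyond the scatter below both the bromo and the iodo compounds. Against bromo, iodo gives a number 7.2 percentage points lower from compound 1 to compound 3 (within the scatter) and so compound 1 and compound 3 cannot be ordered: at this position, the separation so far lies between chloro and the other two halogens. Still open, on these data alone, is how a non-halogen group on this carbon, such as methoxy, trifluoromethyl or an amine, would read. No measurement at hand accounts for the difference between the halogens.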